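The source may hold more compounds than are shown below. What is called first, only, known or untested is meant among the compounds shown, and "the series" means these compounds.

Measured in an ADME assay on CEM-SS cells (Homo sapiens) for cytotoxicity, read by XTT assay, with a stated time of 6 days; on this read-out higher numbers stand for lower toxicity in this test and lower numbers for higher toxicity in this test:
- compound 1 `CCCC(=O)OCSc1ccccc1C(=O)NCCCC(N)=O`: 56.6 uM
- compound 2 `CCCC(=O)OCSc1ccccc1C(=O)NCCCCCCNC(C)=O`: 8 uM
- compound 3 `CCCC(=O)OCSc1ccccc1C(=O)N(C)CC(=O)NC`: 62.5 uM

Compound 3, at 62.5 uM, stands level with compound 1 within the scatter, while compound 2 gives the clearly lower 8 uM. Compound 4 `CCCC(=O)OCSc1ccccc1C(=O)NCC(=O)NC(C)C` carries ((isopropylcarbamoyl)methyl)amino in place of methyl((methylcarbamoyl)methyl)amino on a carbonyl carbon.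

Going by the values given here, the closest precedent is a 1.1-fold higher number from compound 1 to compound 3 (0.04 log units; within the scatter), also a change on a carbonyl carbon, and it stays within the scatter. The larger 7.1-fold lower number from compound 1 to compound 2 (0.85 log units; beyond the scatter) came with 3-acetamidopropyl in place of carbamoyl, a change not repeated here. The expected result is a 1.3-fold lower number from compound 3 to compound 4 (0.10 log units; within the scatter), with no shift beyond the scatter. For compound 4 the estimated value in this assay is 50 uM, with an expected range of 22 uM to 110 uM.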

Compound 4, half-maximal toxic concentration: 92 uM
For compound 4 the middle estimate is 1.8-fold (0.26 log units) below the measured one; low and high end bracket the measured number.
By their numbers in this assay, from the lowest: compound 2; then compounds 1, 3 and 4 (each within the scatter of the next).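

In this assay, ((isopropylcarbamoyl)methyl)amino in place of methyl((methylcarbamoyl)methyl)amino on a carbonyl carbon leaves the number within the scatter (a 1.5-fold higher number from compound 3 to compound 4 (0.17 log units; within the scatter)). Isopropylcarbamoyl in place of 2-carbamoylethyl also stays within the scatter (a 1.6-fold higher number from compound 1 to compound 4 (0.21 log units; within the scatter)), so compounds 1, 3 and 4 form one level. Isopropylcarbamoyl in place of 5-acetamidopentyl gives the only large step here (a 12-fold higher number from compound 2 to compound 4 (1.06 log units; beyond the scatter)), leaving compound 2 apart.

Open, on these data alone, is whether a terminal amine or carboxylic acid on the chain would hold that level. No evidence accounts for these steps.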